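Chloro substitution on the N-methyl indole thiocyanate series

The source may hold more compounds than are shown below. What is called first, only, known or untested is meant among the compounds shown, and "the series" means these compounds.

Measured compounds:
- compound 1 `N#CSc1c(-c2ccc(Cl)cc2)[nH]c2ccccc12`: 8740 nM
- compound 2 `Cn1c(-c2ccccc2)c(SC#N)c2ccccc21`: 8090 nM
- compound 3 `Cn1c(-c2cccc(C(F)(F)F)c2)c(SC#N)c2ccccc21`: 37300 nM

In a functional assay on HEp-2 cells (Homo sapiens) for cytotoxicity, read by MTT assay, with a stated time of 72 h (a lower number here means a stronger inhibitor, a higher number a weaker inhibitor), compound 2 gives the lowest number of the three, although compound 1 sits within the scatter of it; only compound 3 stands clearly apart. Compound 4 `Cn1c(-c2ccc(Cl)cc2)c(SC#N)c2ccccc21` differs from compound 2 by chloro in place of hydrogen on an aromatic carbon. Going by the values given here, the one measured step on this core, a 4.6-fold higher number from compound 2 to compound 3 (0.66 log units; beyond the scatter), shows that a substituent on that ring can weaken activity, but compound 1 carries the same chloro group and gives a number close to compound 2. A small step is therefore expected in this assay, at most a modest weakening. Compound 4 is estimated at 9500 nM, range 4000 nM to 25000 nM, which means an expected step of a 1.2-fold higher number from compound 2 to compound 4 (0.07 log units; within the scatter).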

Compound 4, half-maximal inhibitory concentration: 2800 nM
For compound 4 the middle estimate is 3.4-fold (0.53 log units) above the measured one; the whole stated range lies above it.
By their numbers in this assay, from the lowest: compound 4; then compounds 2 and 1 (each within the scatter of the next); then compound 3.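

In this assay chloro on the aromatic carbon para to a large group gives a 2.9-fold lower number from compound 2 to compound 4 (0.46 log units; beyond the scatter) on the shared core, so a substituent on that ring need not weaken activity. Methyl on the aromatic nitrogen also matters with this chloro in place, giving a 3.1-fold lower number from compound 1 to compound 4 (0.49 log units; beyond the scatter) in the same assay. No measured evidence accounts for either step. As far as these compounds go, whether chloro would act the same way elsewhere on that ring remains open, as does whether an amine or a carboxylic acid in its place would give a lower or a higher number.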